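Nitro for Trifluoromethyl: Solubility Outlook for Compound 4

This account rests on a few compounds, and the source may have more. Where it says the series, first, only, none or still open, it means among the compounds named here.

Compound 1 `O=C(Nc1ccccc1C(F)(F)F)c1cc(Cl)ccc1O` sits at a limit of the assay, > 47 ug/mL.
Compound 2 `O=C(Nc1ccccc1[N+](=O)[O-])c1cc(Cl)ccc1O` gives 15.4 ug/mL.
Compound 3 `O=C(Nc1ccc(C(F)(F)F)c(Cl)c1)c1cc(Br)ccc1O` sits at a limit of the assay, < 1 ug/mL.

In a physicochemical assay for solubility (a higher number here means a more soluble compound, a lower number a less soluble compound), the reading for compound 1 is a limit of the assay, not a number (the limit of > 47 ug/mL in this assay, at which 1 of the 3 values shown sits). Compound 2 gives 15.4 ug/mL, so the step of an at least 3.0-fold lower number from compound 1 to compound 2 (0.48 log units; beyond the scatter) follows the change (nitro in place of trifluoromethyl on an aromatic carbon). For compound 3 the reading is again a limit (the limit of < 1 ug/mL in this assay, at which 1 of the 3 values shown sits); how its core differs from that of compound 1 is not broken down here.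

Compound 4 `O=C(Nc1ccc([N+](=O)[O-])c(Cl)c1)c1cc(Br)ccc1O` has not yet been measured. Its change from compound 3, (nitro in place of trifluoromethyl on an aromatic carbon), is the same kind of change as in compound 2, though the place differs: ortho to a chloro group and para to a large group rather than ortho to a large group. Set beside an at least 3.0-fold lower number from compound 1 to compound 2 (0.48 log units; beyond the scatter), the step that the limit leaves unreadable from compound 3 to compound 4 is expected to be of similar direction, resting on that one measured pair. Compound 4 is therefore estimated at 0.4 ug/mL, with the assay likely to report only a limit again.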

Compound 4, solubility: < 1 ug/mL
Compound 4 ended at the assay's limit; the forecaster's own chance of this, stated with the estimate: 75%; the middle value does not contradict the limit.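

In this assay, going by these compounds alone, compound 4 gives < 1 ug/mL, a limit of the assay, and compound 3 sits at that same limit, so no step between them can be read. The compounds shown leave open how far nitro in place of trifluoromethyl shifts the reading on the core of compound 3.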